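Series notes: losing the trifluoromethyl group

A few compounds are considered here, and "the series" means these few. Any claim that something is new, unique, unknown or untested is made for them only; others in the source may bear on it.

In a functional assay on MCF7 cells (Homo sapiens) for antiproliferative activity, read by MTT assay, with a stated time of 48 h (on this read-out lower numbers stand for stronger inhibition and higher numbers for weaker inhibition), compound 3 `O=C(/C=C/c1ccc(C(F)(F)F)cc1)Nc1nnc(-c2ccc(Cl)cc2)s1` gives 1.65 ug/mL. Compound 1 `Cc1ccc(/C=C/C(=O)Nc2nnc(-c3ccc(Cl)cc3)s2)cc1`, with methyl at the same place, gives 1.44 ug/mL. Compound 2 `COc1ccc(-c2nnc(NC(=O)/C=C/c3ccccc3)s2)cc1` gives 0.78 ug/mL, a lower number than compound 3 by more than the scatter. Compound 4 `O=C(/C=C/c1ccccc1)Nc1nnc(-c2ccc(Cl)cc2)s1` has hydrogen in place of trifluoromethyl on an aromatic carbon. Going by the values given here, the only measured step at this place is a 1.1-fold higher number from compound 1 to compound 3 (0.06 log units; within the scatter), which lies within the scatter. Compound 2, at 0.78 ug/mL, also has hydrogen there but differs elsewhere, so it only weakly suggests a lower number. No change beyond the scatter is expected in this assay, and the estimated step is a 1.3-fold lower number from compound 3 to compound 4 (0.10 log units; within the scatter). Compound 4 is estimated at 1.3 ug/mL, with an expected range of 0.6 ug/mL to 2.8 ug/mL.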

Compound 4, half-maximal inhibitory concentration: 1.42 ug/mL
The estimate for compound 4 lay 1.1-fold (0.04 log units) below the measured number; the measured number falls inside the stated range.
By their numbers in this assay, from the lowest: compounds 2, 4, 1 and 3 (each within the scatter of the next, the first and the last beyond it).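

In this assay hydrogen, methyl and trifluoromethyl on this aromatic carbon are not told apart: the removal of trifluoromethyl gives a 1.2-fold lower number from compound 3 to compound 4 (0.07 log units; within the scatter), and hydrogen in place of methyl gives a 1.0-fold lower number from compound 1 to compound 4 (0.01 log units; within the scatter), so neither group is needed to hold the number. Chloro in place of methoxy on an aromatic carbon gives a 1.8-fold higher number from compound 2 to compound 4 (0.26 log units; within the scatter), which also stays within the scatter. No measurement at hand gives a reason for these results.

From the compounds shown here alone, whether an amine or a carboxylic acid at this place would move the number beyond the scatter remains open. So does whether methoxy here would behave as hydrogen does.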